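Swapping a hydroxyphenyl group for a naphthyl group

A few compounds are considered here, and "the series" means these few. Any claim that something is new, unique, unknown or untested is made for them only; others in the source may bear on it.

Measured in a functional assay on HCT-116 cells (Homo sapiens) for inhibition, read by MTT assay, with a stated time of 48 h; a lower number here means a stronger inhibitor, a higher number a weaker inhibitor:
compound 1 `COc1cc(-c2cc(-c3ccc(C)cc3)nc(-c3ccccc3)n2)cc(OC)c1OC`: 15700 nM
compound 2 `COc1ccc(-c2cc(-c3cc(OC)c(OC)c(OC)c3)nc(-c3ccccc3)n2)cc1`: 4780 nM
compound 3 `COc1cc(-c2cc(-c3ccc(O)cc3)nc(-c3ccccc3)n2)cc(OC)c1OC`: 11900 nM

These three compounds share one core and differ only in a small group on a single aromatic ring. Where compound 3 stands depends on the comparison. Putting hydroxy in place of methyl gives a 1.3-fold lower number from compound 1 to compound 3 (0.12 log units; within the scatter), while going from the methoxy compound to the hydroxy compound gives a 2.5-fold higher number from compound 2 to compound 3 (0.40 log units; beyond the scatter). Its number is therefore level with one neighbour and higher than the other.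

Compound 4 `COc1cc(-c2cc(-c3cccc4ccccc34)nc(-c3ccccc3)n2)cc(OC)c1OC` changes much more, with naphthalen-1-yl in place of 4-hydroxyphenyl on an aromatic carbon. The measured steps bear on this only loosely. Each swaps a small group on the ring that compound 4 replaces, and none replaces the ring itself. The largest of them is a 3.3-fold lower number from compound 1 to compound 2 (0.52 log units; beyond the scatter), and the data give no direction for a swap of the whole ring. A step of no more than similar modest size is therefore expected in this assay, most likely staying within the scatter. The expected change is a 1.3-fold lower number from compound 3 to compound 4 (0.12 log units; within the scatter). For compound 4 the estimate is 9000 nM, expected to fall between 3000 nM and 30000 nM.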

Compound 4, half-maximal inhibitory concentration: 4930 nM
Estimate against measurement, compound 4: 1.8-fold (0.26 log units) above; measured number inside the range.
By their numbers in this assay, from the lowest: compounds 2 and 4 (each within the scatter of the next); then compounds 3 and 1 (each within the scatter of the next).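

In this assay, for the compounds shown here, the earlier compounds changed only a small group on this ring, whereas compound 4 replaces the whole ring, and the position still accepts naphthalen-1-yl, with its 2 six-membered aromatic rings of carbon only: the swap gives a 2.4-fold lower number from compound 3 to compound 4 (0.38 log units; beyond the scatter) and, against the methyl compound, a 3.2-fold lower number from compound 1 to compound 4 (0.50 log units; beyond the scatter) in the same direction. Against the methoxy compound the swap gives a 1.0-fold higher number from compound 2 to compound 4 (0.01 log units; within the scatter) and so leaves the number level, which means that a small methoxy group on the phenyl ring and a whole second aromatic ring give the same result at this place, on an aromatic carbon next to the ring nitrogen. No measurement shown here says why these two quite different groups land level, or why both sit apart from the hydroxy and methyl compounds.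

The compounds shown leave open how an amine or a carboxylic acid on the phenyl ring, or a longer chain such as ethoxy in place of methoxy, would behave at this position. They also leave open whether any group here can give a number clearly lower than the level shared by compound 2 and compound 4.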